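Amide nitrogen substituent in the halophenyl butenamide series

This account rests on a few compounds, and the source may have more. Where it says the series, first, only, none or still open, it means among the compounds named here.

Measured so far:
compound 1, `C/C(C(=O)NC1CC1)=C(/C)c1ccc(Br)cc1`, gives 600 mg/kg in a toxicity assay on the whole organism (strain Icem-CET (SPF Caw)) for cytotoxicity, with Mus musculus as the target; a higher number here means that more compound is needed for the effect, a lower number that less compound is needed
compound 2, `C/C(C(=O)NC1CC1)=C(/C)c1ccc(F)cc1`, gives 200 mg/kg in this assay
compound 3, `C#CCNC(=O)/C(C)=C(\C)c1ccc(Cl)cc1`, gives 400 mg/kg in this assay

Compound 3 stands second highest of the three numbers. Its nearest neighbour is compound 1, whose number is higher by a gap within the scatter; compound 2 is furthest, lower by a gap that is also within the scatter. One step among the measured compounds is established: a 3.0-fold lower number from compound 1 to compound 2 (0.48 log units; beyond the scatter), a modest step beyond the scatter, tied to the aromatic halogen.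

Compound 4, `C/C(C(=O)NC1CC1)=C(/C)c1ccc(Cl)cc1`, differs from compound 3 by cyclopropyl in place of propargyl on an amide-type nitrogen. Going by the values given here, no measured step bears on this change: the single established step concerns the aromatic carbon, not the amide-type nitrogen. What the numbers do show is that compound 1 and compound 2 carry the same cyclopropylamino amide as compound 4, with bromo and fluoro on the aromatic carbon, and their values bracket the value of compound 3. On that basis compound 4 is expected to stay close to compound 3, no change at the digits printed from compound 3 to compound 4 (within the scatter), with no step beyond the scatter in this assay. The estimate for compound 4 is 400 mg/kg, with a range from 200 mg/kg to 800 mg/kg.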

Compound 4, dose for half-maximal effect: > 800 mg/kg
Compound 4: no number, only a limit (the forecaster's own chance of this, stated with the estimate: 5%); middle value at least 2.0-fold (0.30 log units) from the limit.
By their numbers in this assay, from the lowest: compounds 2, 3 and 1 (each within the scatter of the next, the first and the last beyond it). At a limit, above all of these: compound 4.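

Compound 4 gives only a limit, not a number, in this assay: the limit of > 800 mg/kg in this assay, at which 1 of the 4 values shown sits.

Going by these compounds alone, this is the first reading on the amide-type nitrogen with the aromatic chloro held constant: propargylamino to cyclopropylamino gives an at least 2.0-fold higher number from compound 3 to compound 4 (0.30 log units; that floor lies within the scatter), so the change brings no drop in the number, although its floor alone does not establish a rise. Within the cyclopropylamino amides, the aromatic halogen now has three members: chloro in place of fluoro gives an at least 4.0-fold higher number from compound 2 to compound 4 (0.60 log units; beyond the scatter), while chloro in place of bromo gives an at least 1.3-fold higher number from compound 1 to compound 4 (0.12 log units; that floor lies within the scatter), so compound 2, the fluoro member, stands apart from both the bromo and the chloro members, whereas the floor of the chloro-bromo step separates those two by no more than the scatter.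

As far as these compounds go, with only a limit for compound 4, the true size of its steps from compound 3 and compound 1 remains open, and so does whether chloro and bromo differ at all. Also open, from the compounds shown here alone, are whether the nitrogen step holds with bromo or fluoro on the aromatic carbon, and what an ethyl group or a longer alkyl chain on the amide-type nitrogen would give.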